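A few compounds are considered here, and "the series" means these few. Any claim that something is new, unique, unknown or untested is made for them only; others in the source may bear on it.

Going by the values given here, in an ADME assay on Vero cells (Chlorocebus sabaeus) for cytotoxicity, read by trypan blue exclusion, with a stated time of 24 h (a higher number here means a weaker inhibitor, a lower number a stronger inhibitor), only two compounds with the shared core have numbers so far. Compound 3 (`COc1cc(C[C@@H](C)[C@@H](C)Cc2ccc(OC(C)=O)c(OC)c2)ccc1O`) gives 112 ug/mL in this test, and compound 1 (`COc1cc(C[C@@H](C)[C@@H](C)Cc2ccc(OC(=O)c3cccnc3)c(OC)c2)ccc1O`) gives 71.4 ug/mL there. These two values lie within the usual scatter of each other, so compound 3 cannot be separated from compound 1. Compound 2 (`COc1cc(C[C@@H](C)[C@@H](C)Cc2ccc(OC(=O)c3cnccn3)c(OC)c2)ccc1OC(=O)c1cnccn1`) also carries pyrazin-2-yl, but compound 2 has only the entry "not determined" (no result reported) and offers no guidance.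

Compound 4 (`COc1cc(C[C@@H](C)[C@@H](C)Cc2ccc(OC(=O)c3cnccn3)c(OC)c2)ccc1O`) differs from compound 3 in one place, with pyrazin-2-yl in place of methyl on a carbonyl carbon as the whole change. Among the compounds with values here, one measured step bears on this exchange. Going from pyridin-3-yl to methyl at the same kind of place gave a 1.6-fold higher number from compound 1 to compound 3 (0.20 log units; within the scatter) as its result. The new exchange runs the opposite way, from methyl to a ring, although the ring is a different one. With that single precedent from compound 1 and compound 3 staying within the scatter, no step beyond the scatter is expected here. The estimated step is a 1.4-fold lower number from compound 3 to compound 4 (0.15 log units; within the scatter) and is expected to be small. For compound 4 the expected value is 80 ug/mL with an estimated range from 40 ug/mL to 150 ug/mL in this assay when it is measured.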

Compound 4, half-maximal inhibitory concentration: 43.3 ug/mL
Beside the measured number, compound 4's estimate is 1.8-fold (0.27 log units) above it; the range from low to high includes it.
By their numbers in this assay, from the lowest: compounds 4, 1 and 3 (each within the scatter of the next, the first and the last beyond it).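

Placing pyrazin-2-yl instead of methyl on this carbonyl carbon gives a 2.6-fold lower number from compound 3 to compound 4 (0.41 log units; beyond the scatter) in this assay, the first step in this small set to clear the scatter, so the group held at this position can move the number, and here a lower number means a stronger effect on the cells. That does not hold for rings in general: compound 1, with pyridin-3-yl, could not be separated from compound 3, and a 1.6-fold lower number from compound 1 to compound 4 (0.22 log units; within the scatter) leaves the two rings themselves unseparated, so the clear difference appears only between the two ends of a narrow range. No measurement in hand offers an explanation for this step.

On these data alone, with so few compounds, it remains open whether the number depends on having a ring here at all or on the particular ring, and a single modest step is thin support for either reading. As far as these compounds go, how a longer chain, an amine or a carboxylic acid on this carbonyl carbon would compare with methyl and with pyrazin-2-yl also remains unknown.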